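Trading 3-chlorophenyl for 2-methoxyphenyl: what to expect

The source may report more compounds than this note shows. Statements on the series, on what has been measured and on what is new or still open speak of the compounds shown alone.

Compound 1 `O=C(/C=C/c1ccc(O)c(O)c1)N1CCN(c2ccc(F)cc2)CC1` gives 1.44 ug/mL
Compound 2 `O=C(/C=C/c1ccc(O)c(O)c1)N1CCN(c2cccc(Cl)c2)CC1` gives 1.34 ug/mL

In a functional assay on MCF7 cells (Homo sapiens) for antiproliferative activity, read by MTT assay, with a stated time of 48 h (on this read-out higher numbers stand for weaker inhibition and lower numbers for stronger inhibition), compound 2 gives 1.34 ug/mL and lies within the scatter of compound 1 at 1.44 ug/mL so the two cannot be told apart. The next compound to be tested is compound 3 `COc1ccccc1N1CCN(C(=O)/C=C/c2ccc(O)c(O)c2)CC1` which carries 2-methoxyphenyl in place of 3-chlorophenyl on an amine nitrogen in a ring and otherwise keeps the core of compound 2.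

Going by the values given here, only one measured step bears on this change, a swap of one group for another on that same amine nitrogen: a 1.1-fold lower number from compound 1 to compound 2 (0.03 log units; within the scatter) and it stays within the scatter. Among the compounds with values here, this is a single step, and no measured compound carries a methoxy group, so the evidence is thin. No step beyond the scatter is therefore expected in this assay in either direction, though the range has to stay fairly wide. The estimated change is a 1.1-fold higher number from compound 2 to compound 3 (0.05 log units; within the scatter) and it is expected to remain small. Compound 3 is expected at 1.5 ug/mL with an estimated range of 0.7 ug/mL to 3.5 ug/mL around that figure.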

Compound 3, half-maximal inhibitory concentration: 0.54 ug/mL
Estimate against measurement, compound 3: 2.8-fold (0.44 log units) above, outside the stated range (below it).
By their numbers in this assay, from the lowest: compound 3; then compounds 2 and 1 (each within the scatter of the next).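

In this assay, the group on this amine nitrogen does matter, which the first two compounds could not show: the change to 2-methoxyphenyl gives a 2.5-fold lower number from compound 2 to compound 3 (0.39 log units; beyond the scatter), and the same comparison with the 4-fluorophenyl compound gives a 2.7-fold lower number from compound 1 to compound 3 (0.43 log units; beyond the scatter). Both steps are modest but beyond the usual scatter, so compound 3 is the strongest inhibitor of the three on this read-out, while the two halogen-bearing phenyl groups remain indistinguishable from each other. The entering group adds an oxygen and one counted hydrogen-bond acceptor, but no measurement here connects either feature to the lower number, and nothing available explains the change.

The swap alters both the atoms on the phenyl ring and where they sit, and these three compounds cannot separate those two changes. They also leave open how a plain phenyl group, an ethoxyphenyl group or a benzyl group on the same nitrogen would compare, and so whether the methoxy group itself is needed for the lower number.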